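The source may report more compounds than this note shows. Statements on the series, on what has been measured and on what is new or still open speak of the compounds shown alone.

Working notes on the series. In a physicochemical assay for inhibition, with a stated time of 7 days (a lower number here means a stronger inhibitor, a higher number a weaker inhibitor), compound 2 (`O=C(Nc1ccc(Br)cc1)Nc1cccc(Cl)c1`) gives 6400 nM and compound 1 (`COc1ccc(NC(=O)Nc2cccc(Cl)c2)cc1`) gives 7140 nM on the shared core, two values that lie within the scatter of each other. Neither can be ranked ahead of the other. Compound 3 (`Cc1cccc(NC(=O)Nc2cccc(Cl)c2)c1C`) comes out "not active" (no number reported) with no number reported, which keeps open that compound 4 could also yield no number.

The next step leads from compound 2 to compound 4 (`O=C(Nc1ccccc1)Nc1ccc(Br)cc1`). The change is hydrogen in place of chloro on an aromatic carbon and reads as hydrogen in place of chloro on an aromatic carbon.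

Going by the values given here, only one measured step is available, a 1.1-fold lower number from compound 1 to compound 2 (0.05 log units; within the scatter) for bromo in place of methoxy on an aromatic carbon. That step leaves the chloro untouched and bears on the new change only indirectly. Among the compounds with values here, all measured compounds carry the chloro, and the data therefore hold no direct precedent for its removal.

In this assay no shift beyond the scatter is expected, and the slight lean toward a higher number is an assumption rather than a finding. The estimated step is a 1.4-fold higher number from compound 2 to compound 4 (0.15 log units; within the scatter) and carries wide uncertainty. In this assay compound 4 is estimated at 9000 nM (expected range 3500 nM to 25000 nM).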

Compound 4, half-maximal inhibitory concentration: 6100 nM
The estimate for compound 4 lay 1.5-fold (0.17 log units) above the measured number; low and high end bracket the measured number.
By their numbers in this assay, from the lowest: compounds 4, 2 and 1 (each within the scatter of the next).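

In this assay, going by these compounds alone, the first direct reading at this position is a 1.0-fold lower number from compound 2 to compound 4 (0.02 log units; within the scatter), for hydrogen in place of chloro on an aromatic carbon, meta to a large group. Every earlier compound carried the chloro, so the series had not shown whether a reported number depends on it; this pair shows that compound 4, with no chloro and no other change from compound 2, still gives a number, and one within the scatter of the value for compound 2. The finding holds for this one pair, with the bromo in place, and shows only that the loss of this single chlorine atom leaves no readable difference in this assay. No measurement at hand bears on why the two values stay so close.

The compounds shown do not tell whether the same replacement would read the same way with the methoxy of compound 1 in place of the bromo. They also leave open what a group other than hydrogen or chloro, such as an amine or a carboxylic acid, would give at this position.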